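Arylpiperazine variation on the shared core at the serotonin-7 receptor

A few compounds are considered here, and "the series" means these few. Any claim that something is new, unique, unknown or untested is made for them only; others in the source may bear on it.

Measured so far in an assay on membranes from CHO-K1 cells for displacement of a labelled ligand from 5-hydroxytryptamine receptor 7 (Homo sapiens), read by scintillation counting; a higher number here means a weaker inhibitor, a lower number a stronger inhibitor:
compound 1 `COc1cc2ncnc(N3CCC(CN4CCN(c5ccccc5)CC4)C3)c2cc1OC`: 251 nM
compound 2 `COc1cc2ncnc(N3CCC(CN4CCN(c5cccc(Cl)c5)CC4)C3)c2cc1OC`: 372 nM
compound 3 `COc1cc2ncnc(N3CCC(CN4CCN(c5ccc(O)cc5)CC4)C3)c2cc1OC`: only a limit, > 1000 nM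

Compound 3 sits at the limit of this assay the limit of > 1000 nM in this assay, at which 1 of the 3 values shown sits, and so stands lowest of the three on the numbers shown. The next step replaces its terminal ring: pyrimidin-2-yl in place of 4-hydroxyphenyl on an amine nitrogen in a ring, giving compound 4 `COc1cc2ncnc(N3CCC(CN4CCN(c5ncccn5)CC4)C3)c2cc1OC`. Among the measured compounds shown here, two measured steps bear on this position. Adding the hydroxy gave an at least 3.9-fold higher number from compound 1 to compound 3 (0.60 log units; beyond the scatter), and the swap of aryl groups gave an at least 2.6-fold higher number from compound 2 to compound 3 (0.42 log units; beyond the scatter), while the chloro change a 1.5-fold higher number from compound 1 to compound 2 (0.17 log units; within the scatter) stayed within the scatter. Removing the hydroxy-bearing ring is therefore expected to recover potency, an at least 2.0-fold lower number from compound 3 to compound 4 (0.30 log units; that floor lies within the scatter). Compound 4 is estimated at 500 nM, with a range from 150 nM to 2000 nM.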

Compound 4, inhibition constant: > 1000 nM
Compound 4 was reported as a limit (the forecaster's own chance of this, stated with the estimate: 25%); middle value at least 2.0-fold (0.30 log units) away from the limit.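

Pyrimidin-2-yl on the amine nitrogen gives an at least 2.6-fold higher number from compound 2 to compound 4 (0.42 log units; beyond the scatter) and an at least 3.9-fold higher number from compound 1 to compound 4 (0.60 log units; beyond the scatter) in this assay on this series. The loss at this position is therefore not confined to 4-hydroxyphenyl: among the four terminal rings shown, only phenyl and 3-chlorophenyl give values that are not limits. Compound 4 gives a limit, not a number, and shares it with compound 3, so the step between them cannot be read: the limit of > 1000 nM in this assay, at which 2 of the 4 values shown sit.

Open, as far as these compounds go, is whether a 2-methoxyphenyl or pyridin-2-yl group on the same nitrogen gives a value clear of that limit. From the compounds shown here alone, how far compound 3 and compound 4 lie beyond it also stays open.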